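Replacing diisopropylamino in compound 1

A few compounds are considered here, and "the series" means these few. Any claim that something is new, unique, unknown or untested is made for them only; others in the source may bear on it.

In an ADME assay on the whole organism for inhibition, with Oryza sativa as the target, with a stated time of 4 days (on this read-out higher numbers stand for weaker inhibition and lower numbers for stronger inhibition), compound 1 (`CC(C)N(c1nc(Cl)nc(N[C@@H](C)c2ccccc2)n1)C(C)C`) gives 372 nM, the lowest of three numbers, against 6310 nM for compound 2 (`CCN(CC)c1nc(Cl)nc(N[C@H](C)c2ccccc2)n1`) and 5370 nM for compound 3 (`CC(C)Nc1nc(Cl)nc(N[C@H](C)c2ccccc2)n1`). Compound 4 (`CCC(CC)Nc1nc(Cl)nc(N[C@@H](C)c2ccccc2)n1`) carries (pentan-3-yl)amino in place of diisopropylamino on an aromatic carbon. Among the compounds with values here, the one measured step that bears on this, isopropylamino in place of diethylamino on an aromatic carbon, came to a 1.2-fold lower number from compound 2 to compound 3 (0.07 log units; within the scatter). That step comes from compounds with the opposite configuration at the stereocentre to compound 1 and compound 4, so it guides only loosely. No change beyond the scatter is therefore expected, and the estimated step is a 1.6-fold higher number from compound 1 to compound 4 (0.21 log units; within the scatter). The estimate for compound 4 is 600 nM, with an expected range from 150 nM to 2500 nM.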

Compound 4, half-maximal inhibitory concentration: 35500 nM
Compound 4: middle estimate off by 59-fold (1.77 log units), on the low side; the whole stated range lies below it.
By their numbers in this assay, from the lowest: compound 1; then compounds 3 and 2 (each within the scatter of the next); then compound 4.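

In this assay, within the data shown here, putting (pentan-3-yl)amino in place of diisopropylamino gave a 95-fold higher number from compound 1 to compound 4 (1.98 log units; beyond the scatter), so this position can respond strongly, whereas the one earlier step there, a 1.2-fold lower number from compound 2 to compound 3 (0.07 log units; within the scatter), stayed within the scatter and came from the opposite configuration at the stereocentre. The change also brings in 1 hydrogen-bond donor where diisopropylamino has 0 hydrogen-bond donors. Nothing available explains the size of this step.

Going by these compounds, whether that donor or the shape of the chain matters remains open. A methyl group on the nitrogen of (pentan-3-yl)amino, or dipropylamino, would help separate the two.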